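The compounds below may be only part of what the source reports. "The series", "measured", "known", "first", "only" and "open" are said of these compounds alone.

Measured compounds:
compound 1 `ClCc1cccc(Cn2cnc3ncnc(Cl)c32)c1` — in a functional assay on HCT-15 cells (Homo sapiens) for cytotoxicity, read by sulforhodamine B assay, with a stated time of 48 h (on this read-out higher numbers stand for weaker inhibition of growth and lower numbers for stronger inhibition of growth), compound 1 gives 4360 nM
compound 2 `ClCc1ccc(Cn2cnc3c(Cl)nc(Cl)nc32)cc1` — in this assay compound 2 gives 3800 nM

Only these two compounds have been measured, and their two numbers lie within the usual scatter of each other, so compound 1 stands level with compound 2 and is set apart from nothing. Compound 3 `ClCc1cccc(Cn2cnc3nc(Cl)nc(Cl)c32)c1` has not yet been measured. It differs from compound 1 by chloro in place of hydrogen on an aromatic carbon. Within the data shown here, no step between measured compounds is available, so the size of this change cannot be read from a precedent. Among the measured compounds shown here, the one hint is that compound 2, which also carries two chloro groups on its core, gives 3800 nM in this assay, a number within the scatter of compound 1. The step expected is therefore a 1.2-fold lower number from compound 1 to compound 3 (0.08 log units; within the scatter), nothing beyond the scatter in either direction. Compound 3 is estimated at 3600 nM, with a range from 1500 nM to 8500 nM.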

Compound 3, concentration for total growth inhibition: 2130 nM
Compound 3: the middle estimate sits 1.7-fold (0.23 log units) above what was measured, within the range that was stated.
By their numbers in this assay, from the lowest: compounds 3, 2 and 1 (each within the scatter of the next, the first and the last beyond it).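

In this assay, among these compounds, chloro in place of hydrogen on an aromatic carbon, between two ring nitrogen atoms, gives a 2.0-fold lower number from compound 1 to compound 3 (0.31 log units; beyond the scatter), the first change that reaches past the usual scatter. The position therefore accepts a chloro group with no loss of growth inhibition, and the lower number stands for modestly stronger inhibition, a small gain rather than a large one. No measurement available here bears on what lies behind this step.

The compounds shown leave open whether an amine or a methoxy group on that same carbon would extend this step, cancel it or reverse it. They also leave open whether bromo or fluoro there would match chloro, so the step cannot yet be told apart as specific to chloro.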